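This account rests on a few compounds, and the source may have more. Where it says the series, first, only, none or still open, it means among the compounds named here.

Series notes. Compound 1 `O=C(N/N=C/c1cc(I)cc(I)c1O)c1ccccc1` and compound 2 `Cc1ccc(C(=O)N/N=C/c2cc(I)cc(I)c2O)cc1` share one core, compound 2 carrying a methyl in place of hydrogen on an aromatic carbon. In a functional assay on HepG2 cells (Homo sapiens) for cytotoxicity, with a stated time of 24 h (a lower number here means a stronger inhibitor, a higher number a weaker inhibitor), compound 1 gives only a limit, > 50000 nM. In this assay compound 2 likewise gives only a limit, > 25000 nM. Going by the values given here, the one measured step, a step that the two limits leave unreadable from compound 1 to compound 2, thus has no readable size. Compound 3 `O=C(N/N=C/c1cc(I)cc(I)c1O)c1ccc(Br)cc1` carries the change bromo in place of methyl on an aromatic carbon on the same core. Among the compounds with values here, no measured step speaks to this change, and both neighbours sit at limits, so no shift beyond the scatter is expected. The expected step is a step that the limit leaves unreadable from compound 2 to compound 3. Compound 3 is expected to give 40000 nM, within 15000 nM to 100000 nM, most likely again reported as a limit.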

Compound 3, half-maximal inhibitory concentration: 22300 nM
The estimate for compound 3 lay 1.8-fold (0.25 log units) above the measured number; the range from low to high includes it.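

In this assay, compound 3 is the first compound shown with a number rather than a limit, so 4-bromophenyl gives the series a readable value. Bromo in place of hydrogen gives an at least 2.2-fold lower number from compound 1 to compound 3 (0.35 log units; beyond the scatter), the first change at this position shown to exceed the scatter. Bromo in place of methyl gives only an at least 1.1-fold lower number from compound 2 to compound 3 (0.04 log units; that floor lies within the scatter), so this comparison sets no firm size.

The step from compound 1 to compound 2 still cannot be read. On these data alone, whether an amine or a carboxylic acid at this position would give a lower number remains open.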